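Swapping the Triazole of Compound 1 for a Methylpyrazole

The source may hold more compounds than are shown below. What is called first, only, known or untested is meant among the compounds shown, and "the series" means these compounds.

Measured so far:
compound 1, `c1ccc(-c2nc[nH]n2)c(NCC2=NCCN2)c1`, gives 100%
compound 2, `Cc1ccc(-c2ccccc2NCC2=NCCN2)n1C`, gives 0%
compound 3, `CCCCn1ncnc1-c1ccccc1NCC1=NCCN1`, gives 83%

Of the compounds shown here, three built on a shared core have been tested in a functional assay with Alpha-1B adrenergic receptor (Homo sapiens) as the target, read by calcium flux; a higher number here means a larger maximal response, a lower number a smaller maximal response. Compound 1 stands highest of the three numbers. Its nearest neighbour is compound 3, whose maximal response lies lower by more than the usual scatter, and compound 2 lies furthest away, giving no response at all.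

Compound 4, `Cn1cc(-c2ccccc2NCC2=NCCN2)cn1`, has not yet been measured. It differs from compound 1 in a single place: 1-methyl-1H-pyrazol-4-yl in place of 1H-1,2,4-triazol-3-yl on an aromatic carbon. The measured neighbours point in opposite directions: compound 3, with a different five-membered ring in the same place, keeps much of the response, whereas compound 2, with yet another ring there, gives none. In this assay the expected step is a number 45 percentage points lower from compound 1 to compound 4 (beyond the scatter), downward and beyond the scatter, though with wide uncertainty. Compound 4 is therefore estimated at 55%, within a range from 10% to 95%.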

Compound 4, largest response reached (reported as maximal response), in percent of the reference or control that the assay uses: 0%
The estimate for compound 4 lay 55 percentage points above the measured number; the measured number lies below the stated range.
By their numbers in this assay, from the lowest: compounds 2 and 4 (each within the scatter of the next); then compound 3; then compound 1.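

In this assay, replacing 1H-1,2,4-triazol-3-yl with 1-methyl-1H-pyrazol-4-yl on this aromatic carbon gives a number 100 percentage points lower from compound 1 to compound 4 (beyond the scatter), so a single change at this place can remove the entire response. The swap alters several things at once: one ring nitrogen is lost, a methyl group is gained, and the hydrogen-bond donors of the group fall from 1 to 0, so the step cannot be assigned to any one of these. Nothing available gives a measured reason for the loss.

Still open, on these data alone, is whether the loss follows the pyrazole ring or its methyl group. An unsubstituted 1H-pyrazol-4-yl and a 1-methyl-1H-1,2,4-triazol-3-yl at this place would separate those two changes.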